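A dichlorophenyl swap on the sulfonamide nitrogen

This account rests on a few compounds, and the source may have more. Where it says the series, first, only, none or still open, it means among the compounds named here.

Going by the values given here, in a functional assay on PC-3 cells (Mus musculus) for cytotoxicity against PC-3 (Homo sapiens) (on this read-out lower numbers stand for stronger inhibition and higher numbers for weaker inhibition), compound 1 `CCCN(CCC)c1c([N+](=O)[O-])cc(S(=O)(=O)Nc2ccc(Cl)cc2)cc1[N+](=O)[O-]` gives 16000 nM and compound 2 `CCCN(CCC)c1c([N+](=O)[O-])cc(S(=O)(=O)Nc2cccc(C)c2)cc1[N+](=O)[O-]` gives 25000 nM, so compound 2 stands within the scatter of the only other measured compound. Compound 3 `CCCN(CCC)c1c([N+](=O)[O-])cc(S(=O)(=O)Nc2ccc(Cl)c(Cl)c2)cc1[N+](=O)[O-]` carries 3,4-dichlorophenyl in place of 3-methylphenyl on a sulfonamide nitrogen. Among the compounds with values here, the one measured step bearing on this, also an exchange of aryl groups at that nitrogen, is a 1.6-fold higher number from compound 1 to compound 2 (0.19 log units; within the scatter). It stays small, so no change beyond the scatter is expected in this assay. The expected step is a 1.6-fold lower number from compound 2 to compound 3 (0.19 log units; within the scatter). For compound 3 the estimate is 16000 nM, with an expected range of 6000 nM to 40000 nM.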

Compound 3, half-maximal inhibitory concentration: 15000 nM
Compound 3: middle estimate off by 1.1-fold (0.03 log units), on the high side; the measured number falls inside the stated range.
By their numbers in this assay, from the lowest: compounds 3, 1 and 2 (each within the scatter of the next).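

Chloro in place of hydrogen on an aromatic carbon gives a 1.1-fold lower number from compound 1 to compound 3 (0.03 log units; within the scatter) in this assay, and 3,4-dichlorophenyl in place of 3-methylphenyl on a sulfonamide nitrogen gives a 1.7-fold lower number from compound 2 to compound 3 (0.22 log units; within the scatter). All three aryl groups at this nitrogen therefore read alike, and adding a second chloro to the ring does not separate compound 3 from compound 1. No evidence is available to explain this result. Still open, from the compounds shown here alone, is whether a carboxylic acid or an amine on the ring, or a longer alkyl chain in place of the aryl group, would give a step beyond the scatter.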